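This account rests on a few compounds, and the source may have more. Where it says the series, first, only, none or still open, it means among the compounds named here.

Compound 1 `N#CCCCCc1nc(O)cc(O)n1`: in a functional assay on HEK293 cells for agonist activity at G-protein coupled receptor 84 (Homo sapiens), read by calcium flux (on this read-out higher numbers stand for an effect only at larger amounts of compound and lower numbers for an effect already at smaller amounts), compound 1 gives only a limit, > 100000 nM.
Compound 2 `CC(C)CCCc1nc(O)cc(O)n1`: in this assay compound 2 gives 2110 nM.

Going by the values given here, of these two entries, compound 2 is the only one with an actual number; the other entry is a limit of the assay, (the limit of > 100000 nM in this assay, at which 1 of the 2 values shown sits), and says only that no effect was seen within the tested amounts. Among the compounds with values here, the single measured step, an at least 47-fold lower number from compound 1 to compound 2 (1.67 log units; beyond the scatter), is a large shift, but it exchanges a cyanomethyl for an isopropyl and so speaks only loosely to the change at hand. Compound 3 `CCCCCCc1nc(O)cc(O)n1` has not yet been measured. It differs from compound 2 by propyl in place of isopropyl on a saturated chain carbon, three bonds along the chain from an aromatic carbon, the same atoms joined differently. Within the data shown here, no measured step compares a branched chain end with a straight one, so no shift beyond the scatter is expected in this assay for this change. Compound 3 is therefore estimated at 1600 nM, with a range from 500 nM to 6000 nM. That estimate would mean a step of a 1.3-fold lower number from compound 2 to compound 3 (0.12 log units; within the scatter), expected to stay within the usual scatter.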

Compound 3, half-maximal effective concentration: 454 nM
Compound 3: middle estimate off by 3.5-fold (0.55 log units), on the high side; the whole stated range lies above it.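

In this assay, propyl in place of isopropyl gives a 4.6-fold lower number from compound 2 to compound 3 (0.67 log units; beyond the scatter). Going by these compounds alone, the two groups have the same atoms, joined differently, so this is the first sign that the way the carbons at the chain end are joined matters at this position, and not just which atoms are there. The wider comparison, ethyl in place of cyano on a saturated chain carbon, four bonds along the chain from an aromatic carbon, gives an at least 220-fold lower number from compound 1 to compound 3 (2.34 log units; beyond the scatter), but it spans more than the chain end alone and rests on a value for compound 1 that is a limit and not a number: the limit of > 100000 nM in this assay, at which 1 of the 3 values shown sits.

As far as these compounds go, with only one straight chain end and one branched chain end measured with a number, it remains open whether the gain from the straight chain would continue with a longer chain such as heptyl or octyl. From the compounds shown here alone, it is equally open how the number would respond to a carboxylic acid or an amine at the end of the chain, or to a branch placed further along it.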